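The source may hold more compounds than are shown below. What is called first, only, known or untested is meant among the compounds shown, and "the series" means these compounds.

In a functional assay on HL-60 cells (Homo sapiens) for antiproliferative activity, with a stated time of 24 h (a lower number here means a stronger inhibitor, a higher number a weaker inhibitor), two compounds sharing one core have been measured so far, and they differ only in the group on a saturated chain carbon bound to an amine nitrogen in a ring. Compound 1 `Cc1ccccc1CN1CCc2c(sc(NC(=O)c3ccccc3Cl)c2C(N)=O)C1` gives > 50000 nM, which is a limit of the assay and not a number. Among the compounds with values here, compound 2 `NC(=O)c1c(NC(=O)c2ccccc2Cl)sc2c1CCN(Cc1ccc([N+](=O)[O-])cc1)C2` gives 11400 nM, the only true number so far, and it is still a weak result in plain terms.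

Compound 3 `NC(=O)c1c(NC(=O)c2ccccc2Cl)sc2c1CCN(Cc1ccc(Cl)cc1Cl)C2` changes the same place: 2,4-dichlorophenyl in place of 4-nitrophenyl on a saturated chain carbon bound to an amine nitrogen in a ring. Within the data shown here, only one measured step bears on this change, namely an at least 4.3-fold lower number from compound 1 to compound 2 (0.64 log units; beyond the scatter). On these data alone, that step shows that this position can move the result by a modest amount or more, and its full size is unknown. Among the measured compounds shown here, compound 2 is also the only compound here with 4-nitrophenyl, so removing that group may give back part of the step, though a single step is thin support. The expected change is a 2.2-fold higher number from compound 2 to compound 3 (0.34 log units; beyond the scatter), a modest rise in the number. For compound 3 the estimate is 25000 nM, with an expected range of 8000 nM to 50000 nM.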

Compound 3, half-maximal inhibitory concentration: 8010 nM
Beside the measured number, compound 3's estimate is 3.1-fold (0.49 log units) above it; the range from low to high includes it.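

In this assay, swapping 4-nitrophenyl for 2,4-dichlorophenyl gives a 1.4-fold lower number from compound 2 to compound 3 (0.15 log units; within the scatter), so compound 2 and compound 3 cannot be told apart, even though the entering group has 0 hydrogen-bond acceptors and the leaving group has 2. The earlier step could have been read as something special to 4-nitrophenyl, but a second group now gives an at least 6.2-fold lower number from compound 1 to compound 3 (0.79 log units; beyond the scatter), so the difference from compound 1 is not tied to that one group. Compound 1 has a limit of the assay and not a number, so the full size of this step remains unknown: the limit of > 50000 nM in this assay, at which 1 of the 3 values shown sits.

On these data alone, all three compounds carry a phenyl ring with other groups on it at this position, so it remains open how a plain phenyl, a pyridine ring or a longer alkyl chain would read here. As far as these compounds go, compound 2 and compound 3 are still weak in plain terms, and it is also open whether any group at this position, or a change elsewhere on the shared core, can bring the number much lower.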